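The source may report more compounds than this note shows. Statements on the series, on what has been measured and on what is new or still open speak of the compounds shown alone.

The study follows a set of closely related compounds examined in an assay on isolated protein with Bile acid receptor (Homo sapiens) as the target; on this read-out higher numbers stand for an effect only at larger amounts of compound and lower numbers for an effect already at smaller amounts. Within the data shown here, compound 1 `COC(=O)/C=C/c1cccc(N(Cc2ccc(/C=C/C(=O)OC(C)(C)C)cc2OC)C(=O)C2CCCCC2)c1` is the first of them. In this assay compound 1 returns only a limit, > 1000 nM. Compound 2 `COC(=O)/C=C/c1cccc(N(Cc2ccc(/C=C/C(=O)OC(C)(C)C)cc2OCc2ccccc2)C(=O)C2CCCCC2)c1` is the second. In this assay compound 2 likewise returns only a limit, > 1000 nM. Compound 3 `COC(=O)/C=C/c1cccc(N(Cc2ccc(/C=C/C(=O)OC(C)(C)C)cc2OC(C)=O)C(=O)C2CCCCC2)c1` is the third. In this assay compound 3 again returns only a limit, > 1000 nM; with two further limits beside it, its standing among the measured compounds cannot be placed. The steps a step that the two limits leave unreadable from compound 1 to compound 2, a step that the two limits leave unreadable from compound 1 to compound 3 and a step that the two limits leave unreadable from compound 2 to compound 3 therefore carry no readable size, because every value sits at the limit of > 1000 nM in this assay, at which 3 of the 3 values shown sit.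

Compound 4 `COC(=O)/C=C/c1cccc(N(Cc2ccc(/C=C/C(=O)OC(C)(C)C)cc2OC(=O)c2ccccc2)C(=O)C2CCCCC2)c1` differs from compound 3 by phenyl in place of methyl on a carbonyl carbon. Among the measured compounds shown here, since none of the measured steps can be read, no direction is set for this change, and the expectation is that compound 4 will again be reported as a limit. In this assay compound 4 is estimated near 3000 nM, with a range from 800 nM to 20000 nM. The step that the limit leaves unreadable from compound 3 to compound 4 is accordingly expected to be small.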

Compound 4, half-maximal effective concentration: > 1000 nM
Compound 4 ended at the assay's limit; the forecaster's own chance of this, stated with the estimate: 80%; the middle value does not contradict the limit.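

The steps from compound 1, compound 2 and compound 3 to compound 4 cannot be read in this assay, because all four compounds share one limit: the limit of > 1000 nM in this assay, at which 4 of the 4 values shown sit.

The compounds shown leave open whether methyl, benzyl, acetyl and benzoyl on the oxygen on the aromatic ring differ at all in this assay.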